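A few compounds are considered here, and "the series" means these few. Any claim that something is new, unique, unknown or untested is made for them only; others in the source may bear on it.

In a functional assay on MDA-MB-231 cells (Homo sapiens) for inhibition, read by MTT assay, with a stated time of 48 h (a lower number here means a stronger inhibitor, a higher number a weaker inhibitor), compound 1 (`C(=C/c1nc2ccccn2c1Sc1ccccc1)\c1ccccc1`) gives 25300 nM. Compound 3 (`CS(=O)(=O)c1ccc(-c2nc3ccccn3c2Sc2cccc3ccccc23)cc1`) gives 24100 nM, level with compound 1 within the scatter. Compound 2 (`c1ccc(Sc2c(-c3ccccc3)nc3ccc(-c4ccccc4)cn23)cc1`) gives 76700 nM, a higher number than compound 1 and beyond the scatter, so it is the weaker inhibitor of that pair.

Compound 4 (`c1ccc(Sc2c(-c3ccsc3)nc3ccccn23)cc1`) has not yet been measured. It carries thiophen-3-yl in place of the 2-phenylethenyl group of compound 1, on an aromatic carbon of the five-membered aromatic ring with 2 nitrogen, while the phenylsulfanyl group stays: thiophen-3-yl in place of 2-phenylethenyl on an aromatic carbon. Among the compounds with values here, no measured pair here differs in one place alone, so the data give no direct guide to this change. The expectation therefore starts from compound 1 at 25300 nM, and no shift beyond the scatter is foreseen in this assay, with only a slight lean towards a higher number. The expected change is a 1.2-fold higher number from compound 1 to compound 4 (0.07 log units; within the scatter). For compound 4 the estimated value is 30000 nM, with an expected range of 12000 nM to 70000 nM.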

Compound 4, half-maximal inhibitory concentration: 62800 nM
Compound 4: middle estimate off by 2.1-fold (0.32 log units), on the low side; the range from low to high includes it.
By their numbers in this assay, from the lowest: compounds 3 and 1 (each within the scatter of the next); then compounds 4 and 2 (each within the scatter of the next).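

In this assay, within the data shown here, putting thiophen-3-yl in place of 2-phenylethenyl on this aromatic carbon gives a 2.5-fold higher number from compound 1 to compound 4 (0.39 log units; beyond the scatter), a modest step beyond the scatter and the first comparison here in which only one place differs. It shows that the number responds to the group at this position, with compound 4 the weaker inhibitor of the pair while the phenylsulfanyl group stays. The change swaps several features at once, including ring type, heavy-atom count and the double bond outside the rings, and nothing available here bears on why the number moved. The compounds shown leave open which of those features matters, since this single pair cannot separate them. They also leave open how an amine, a carboxylic acid or a longer alkyl chain on this carbon would read.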